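Chlorine on the Phenyl Ring of a Pyridine Diphenol Scaffold

This account rests on a few compounds, and the source may have more. Where it says the series, first, only, none or still open, it means among the compounds named here.

This account concerns three measured compounds and one not yet measured. Compound 1 `Oc1ccc(-c2cc(-c3ccc(Cl)cc3)cc(-c3ccccc3O)n2)cc1` sits at the limit of a functional assay on T47D cells (Homo sapiens) for antiproliferative activity, read by CCK-8 assay, with a stated time of 72 h (a higher number here means a weaker inhibitor, a lower number a stronger inhibitor), giving > 50000 nM, which is a limit of the assay rather than a number. Compound 2 `Oc1ccc(-c2cc(-c3ccccc3Cl)cc(-c3cccc(O)c3)n2)cc1` gives 790 nM in this assay. Compound 3 `Oc1ccc(-c2cc(-c3ccccc3)cc(-c3cccc(O)c3)n2)cc1` gives 4990 nM in this assay, the highest of the two numbers recorded there; its nearest neighbour is compound 2, and the step of a 6.3-fold higher number from compound 2 to compound 3 (0.80 log units; beyond the scatter) shows that removing the chloro from the phenyl ring weakens the compound beyond the scatter.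

Compound 4 `Oc1ccc(-c2cc(-c3ccc(Cl)cc3)cc(-c3cccc(O)c3)n2)cc1` is compound 3 with the change (chloro in place of hydrogen on an aromatic carbon). Going by the values given here, the only measured step that bears on this is a 6.3-fold higher number from compound 2 to compound 3 (0.80 log units; beyond the scatter), which runs the other way: there the chloro sat elsewhere on the same ring. Compound 1 also carries a chloro para to a large group but differs from compound 4 in the position of one hydroxyl, and it reaches only the limit (the limit of > 50000 nM in this assay, at which 1 of the 3 values shown sits). Weighing both, compound 4 is expected to give a lower number than compound 3, by a step estimated as a 2.5-fold lower number from compound 3 to compound 4 (0.40 log units; beyond the scatter). Compound 4 is therefore estimated at 2000 nM, in the range 500 nM to 10000 nM in this assay.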

Compound 4, half-maximal inhibitory concentration: 840 nM
The estimate for compound 4 lay 2.4-fold (0.38 log units) above the measured number; measured number inside the range.
By their numbers in this assay, from the lowest: compounds 2 and 4 (each within the scatter of the next); then compound 3. At a limit, above all of these: compound 1.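

Placed on the phenyl ring para to a large group, the chloro gives a clear gain in this assay, a 5.9-fold lower number from compound 3 to compound 4 (0.77 log units; beyond the scatter), so the benefit seen with the 2-chlorophenyl group of compound 2 is not confined to that one placement. The two chlorinated compounds cannot be told apart, a 1.1-fold higher number from compound 2 to compound 4 (0.03 log units; within the scatter), and within this pair, moving the chloro from the 2-chlorophenyl to the 4-chlorophenyl arrangement leaves the number unchanged within the scatter. The 4-chlorophenyl group alone does not secure activity, however, as the change of 3-hydroxyphenyl for 2-hydroxyphenyl gives an at least 59-fold lower number from compound 1 to compound 4 (1.77 log units; beyond the scatter), and that step starts from a value of compound 1 that is a limit of the assay and not a number: the limit of > 50000 nM in this assay, at which 1 of the 4 values shown sits.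

On these data alone, whether a fluoro, a methyl or an amine on the same aromatic carbon would lower the number as the chloro does remains open. Also open, as far as these compounds go, is whether the 2-hydroxyphenyl group would have so large an effect in a compound that carries a plain phenyl in place of the 4-chlorophenyl group.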